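Swapping hydroxy for bromo on a weak quinoline urea

This account rests on a few compounds, and the source may have more. Where it says the series, first, only, none or still open, it means among the compounds named here.

Of the compounds shown here, two sharing one core have been measured. In a functional assay on HeLa cells (Homo sapiens) for inhibition, read by MTT assay, with a stated time of 72 h (on this read-out higher numbers stand for weaker inhibition and lower numbers for stronger inhibition), compound 1 `COc1cc(NC(C)CCCNC(=O)NNC(=O)Nc2cc(C(F)(F)F)cc(C(F)(F)F)c2)c2ncccc2c1` gives 17000 nM, and compound 2 `COc1cc(NC(C)CCCNC(=O)Nc2ccc(O)cc2)c2ncccc2c1` gives 70000 nM, the higher of the two numbers, with the gap to compound 1 beyond the usual scatter. Compound 3 `COc1cc(NC(C)CCCNC(=O)Nc2ccc(Br)cc2)c2ncccc2c1` differs from compound 2 by a single change: bromo in place of hydroxy on an aromatic carbon. Within the data shown here, no measured pair shows this change, so its size is unknown; the author expects a moderate step toward a lower number, a 2.0-fold lower number from compound 2 to compound 3 (0.30 log units; within the scatter), in this assay. For compound 3 the estimate is 35000 nM, within 12000 nM to 100000 nM.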

Compound 3, half-maximal inhibitory concentration: 20000 nM
Compound 3: middle estimate off by 1.8-fold (0.24 log units), on the high side; measured number inside the range.
By their numbers in this assay, from the lowest: compounds 1 and 3 (each within the scatter of the next); then compound 2.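

At this aromatic carbon, the change from hydroxy to bromo now has a measured size: in this assay it gives a 3.5-fold lower number from compound 2 to compound 3 (0.54 log units; beyond the scatter) and so goes beyond the usual scatter. The read-out therefore responds to the group at this place, although compound 3 still reads 20000 nM and so stays in the same weak range. Nothing available explains the step. The compounds shown leave open whether a chloro or methyl group on the same carbon would match bromo, and where an amine there would fall.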